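This account rests on a few compounds, and the source may have more. Where it says the series, first, only, none or still open, it means among the compounds named here.

Measured compounds:
Compound 1 `COc1ccc(C=C(C(=O)/C=C/c2cccc(OC)c2OC)C(=O)/C=C/c2cccc(OC)c2OC)cc1OC` — 560 nM
Compound 2 `COc1cccc(/C=C/C(=O)C(=Cc2ccc(O)c(F)c2)C(=O)/C=C/c2cccc(OC)c2OC)c1OC` — 300 nM
Compound 3 `COc1ccc(OC)c(/C=C/C(=O)C(=Cc2ccc(OC)c(OC)c2)C(=O)/C=C/c2cc(OC)ccc2OC)c1` — 850 nM

All three were tested in a functional assay on MCF7 cells (Homo sapiens) for antiproliferative activity, read by sulforhodamine B assay, with a stated time of 48 h; on this read-out higher numbers stand for weaker inhibition and lower numbers for stronger inhibition. Compound 2 differs from compound 1 by 3-fluoro-4-hydroxyphenyl in place of 3,4-dimethoxyphenyl on a double-bonded chain carbon bound to a double-bonded chain carbon, and this change gave a 1.9-fold lower number from compound 1 to compound 2 (0.27 log units; within the scatter). Compound 3 carries a different core from compound 1; the difference between the two cores is not broken down here. Compound 3 shows the highest of the three numbers, and against compound 2 the gap lies beyond the scatter, while against compound 1 it does not.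

Compound 4 `COc1ccc(OC)c(/C=C/C(=O)C(=Cc2ccc(O)c(F)c2)C(=O)/C=C/c2cc(OC)ccc2OC)c1` has not yet been measured. It differs from compound 3 by 3-fluoro-4-hydroxyphenyl in place of 3,4-dimethoxyphenyl on a double-bonded chain carbon bound to a double-bonded chain carbon, the same change seen from compound 1 to compound 2. On the basis of a 1.9-fold lower number from compound 1 to compound 2 (0.27 log units; within the scatter), compound 4 is expected to give 450 nM in this assay, the step of a 1.9-fold lower number from compound 3 to compound 4 (0.28 log units; within the scatter) being estimated, with a range of 200 nM to 1000 nM.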

Compound 4, half-maximal inhibitory concentration: 460 nM
The estimate for compound 4 lay 1.0-fold (0.01 log units) below the measured number, within the range that was stated.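

In this assay, putting 3-fluoro-4-hydroxyphenyl in place of 3,4-dimethoxyphenyl on the core of compound 3 gave a 1.8-fold lower number from compound 3 to compound 4 (0.27 log units; within the scatter), and this step matches the earlier one: the same change on two cores in this assay, a 1.9-fold lower number (0.27 log units; within the scatter) from compound 1 to compound 2 and a 1.8-fold lower number (0.27 log units; within the scatter) from compound 3 to compound 4, 1.0-fold (0.00 log units) apart, within the scatter of two such steps. On these two cores, then, the change carried over with a step of the same size. This does not show that the change reliably alters the number, as each step on its own lies within the scatter, and two cores cannot speak for any other core in the series.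

The compounds shown leave open what the fluorine and the hydroxy group each contribute on their own. They also leave open how a phenyl ring carrying an amine or a carboxylic acid would read on the same double-bonded chain carbon.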